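The source may hold more compounds than are shown below. What is called first, only, known or untested is meant among the compounds shown, and "the series" means these compounds.

Measured so far:
- compound 1, `O=C(O)CCC(=O)N(C1CC1)[C@H]1c2ccccc2N(C(=O)c2cccc(OC(F)(F)F)c2)[C@H]2CC[C@H]21`, in a functional assay on cells for antagonist activity at prostaglandin D2 receptor 2 (Homo sapiens), read by chemiluminescence and beta-arrestin recruitment, with stated times of 30 min and 60 min (on this read-out lower numbers stand for stronger inhibition and higher numbers for weaker inhibition), gives 43 nM
- compound 2, `O=C(O)CCC(=O)N(C1CC1)[C@H]1c2ccccc2N(C(=O)c2ccc(OC(F)(F)F)cc2)[C@H]2CC[C@H]21`, in this assay gives 24 nM

Among the measured compounds shown here, compound 2 has the lowest of the two numbers so far, but its only neighbour is compound 1, and the step of a 1.8-fold lower number from compound 1 to compound 2 (0.25 log units; within the scatter) is too small to call a real difference between the two. Compound 3, `O=C(O)CCC(=O)N(C1CC1)[C@H]1c2ccccc2N(C(=O)c2ccc(F)cc2)[C@H]2CC[C@H]21`, has not yet been measured. It differs from compound 2 in one place: fluoro in place of trifluoromethoxy on an aromatic carbon, that is, the trifluoromethoxy group leaves and a single fluorine takes its place on the same aromatic carbon.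

For the measured compounds named here, no measured step matches this change. Going by the values given here, the one step known, from compound 1 to compound 2, moves the trifluoromethoxy group around the ring rather than swapping it for another group, so it says nothing direct about what a smaller substituent does there. With no guide, the expectation for compound 3 is a modest rise in the number, a step of about a 2.5-fold higher number from compound 2 to compound 3 (0.40 log units; beyond the scatter) in this assay, while staying in the same general region as compound 2. The estimate for compound 3 is therefore 60 nM, with a range from 20 nM to 180 nM.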

Compound 3, half-maximal inhibitory concentration: 12 nM
Compound 3: middle estimate off by 5.0-fold (0.70 log units), on the high side, outside the stated range (below it).
By their numbers in this assay, from the lowest: compounds 3, 2 and 1 (each within the scatter of the next, the first and the last beyond it).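

In this assay, the position para to a large group tolerates a much smaller substituent: trifluoromethoxy, with 5 heavy atoms, gives way to fluoro, with a single heavy atom, in the step of a 2.0-fold lower number from compound 2 to compound 3 (0.30 log units; within the scatter). So the larger group is not required here for a number in this range, which compound 1 and compound 2 alone could not show. Among the compounds shown here, the step of a 3.6-fold lower number from compound 1 to compound 3 (0.55 log units; beyond the scatter) is modest, but it is the first in this set to pass the scatter, although it changes both the group and its place on the ring, so the two contributions cannot be separated; no available measurement offers an explanation for these results.

On these data alone, what a chlorine, a methoxy group, a nitrile or an amine would do on the same aromatic carbon remains open, as does whether a plain hydrogen there, with no substituent at all, would hold up as well. The rest of the molecule is identical in all three compounds, so these numbers say nothing about changes elsewhere.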